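From (thiophen-2-yl)carbonyl to 4-fluorobenzyl

The source may hold more compounds than are shown below. What is called first, only, known or untested is meant among the compounds shown, and "the series" means these compounds.

Measured in an ADME assay on CHO cells (Cricetulus griseus) for cytotoxicity, read by MTT assay; a lower number here means a stronger inhibitor, a higher number a weaker inhibitor:
- Compound 1 `CCc1ccc(C(=O)/C=C/c2ccc(CN3CCCCC3)c(O)c2)cc1`: 6590 nM
- Compound 2 `O=C(CCc1ccc(CN2CCCCC2)c(O)c1)c1cccs1`: 168000 nM
- Compound 3 `COc1ccc(CCCc2ccc(CN3CCCCC3)c(O)c2)cc1`: 69800 nM; 211000 nM (2 entries)

Compound 2, at 168000 nM, stands well above compound 1, at 6590 nM, a gap beyond the scatter. The two entries for compound 3 fall on either side of compound 2, so no single order can be given for that pair. The spread is shown by the several entries of compound 3 in this assay, 69800 nM; 211000 nM (2 entries).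

The compound still to be measured is compound 4 `Oc1cc(CCCc2ccc(F)cc2)ccc1CN1CCCCC1`. The change is 4-fluorobenzyl in place of (thiophen-2-yl)carbonyl on a saturated chain carbon, two bonds along the chain from an aromatic carbon. Among the compounds with values here, no measured step shows what this exchange does, so the expectation rests on the high values of compound 2 and compound 3. In this assay a small step to a lower number is expected, one that stays within the scatter: a 1.7-fold lower number from compound 2 to compound 4 (0.23 log units; within the scatter). For compound 4 the estimated value is 100000 nM, with an expected range from 40000 nM to 250000 nM.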

Compound 4, half-maximal inhibitory concentration: 163000 nM
Beside the measured number, compound 4's estimate is 1.6-fold (0.21 log units) below it; the measured number falls inside the stated range.
By their numbers in this assay, from the lowest: compound 1; then compounds 4 and 2 (each within the scatter of the next).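

In this assay, putting 4-fluorobenzyl in place of (thiophen-2-yl)carbonyl on a saturated chain carbon, two bonds along the chain from an aromatic carbon, gives a 1.0-fold lower number from compound 2 to compound 4 (0.01 log units; within the scatter). Within the data shown here, this is the first step that can be read at this place, and it shows that a six-membered aromatic ring of carbon only can stand in for a five-membered aromatic ring with 1 hetero atom and its carbonyl, with the two numbers remaining within the scatter of each other. The step is also small beside the spread of the repeated entries: the several entries of compound 3 in this assay, 69800 nM; 211000 nM (2 entries).

From the compounds shown here alone, the ring and the carbonyl are exchanged together here, so what each contributes on its own stays open, and a phenyl ketone would separate the two. Going by these compounds, whether a carboxylic acid or a primary amine at this place would give a number outside the scatter also remains open.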